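This account rests on a few compounds, and the source may have more. Where it says the series, first, only, none or still open, it means among the compounds named here.

Among the measured compounds shown here, in a functional assay on ECa-109 cells (Homo sapiens) for antiproliferative activity, read by MTT assay, with a stated time of 72 h (on this read-out lower numbers stand for stronger inhibition and higher numbers for weaker inhibition), compound 3 (`CCCSc1nc(N/N=C/c2c(O)ccc3ccccc23)c2nnn(Cc3ccccc3)c2n1`) gives 9290 nM, the lowest of the three numbers so far. Compound 1 (`CCCSc1nc(N/N=C/c2ccc(N(C)C)cc2)c2nnn(Cc3ccccc3)c2n1`) gives 20000 nM, and compound 2 (`CCCSc1nc(N/N=C(\C)c2ccccc2)c2nnn(Cc3ccccc3)c2n1`) gives 32200 nM. Compound 4 (`CCCSc1nc(N/N=C/c2ccccc2)c2nnn(Cc3ccccc3)c2n1`) has not yet been measured. It carries phenyl in place of 2-hydroxynaphthalen-1-yl on a carbon with a double bond to nitrogen. For the measured compounds named here, the one measured step that bears on this change, a 2.2-fold lower number from compound 1 to compound 3 (0.33 log units; beyond the scatter), was modest and also involved 2-hydroxynaphthalen-1-yl, so a step of similar size towards a higher number is expected in this assay. The estimated step is a 2.2-fold higher number from compound 3 to compound 4 (0.33 log units; beyond the scatter). The estimate for compound 4 is 20000 nM, with an expected range from 9000 nM to 45000 nM.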

Compound 4, half-maximal inhibitory concentration: > 64000 nM
Compound 4 ended at the assay's limit; the forecaster's own chance of this, stated with the estimate: 3%; at least 3.2-fold (0.50 log units) between middle value and limit.
By their numbers in this assay, from the lowest: compound 3; then compounds 1 and 2 (each within the scatter of the next). At a limit, above all of these: compound 4.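

Compound 4 stands at a limit of the assay, not at a number: the limit of > 64000 nM in this assay, at which 1 of the 4 values shown sits.

Even so, plain phenyl on this carbon clearly loses inhibition against both substituted partners: replacing 2-hydroxynaphthalen-1-yl gives an at least 6.8-fold higher number from compound 3 to compound 4 (0.83 log units; beyond the scatter), and hydrogen in place of dimethylamino gives an at least 3.2-fold higher number from compound 1 to compound 4 (0.50 log units; beyond the scatter), whereas the third step, an at least 1.9-fold higher number from compound 2 to compound 4 (0.29 log units; that floor lies within the scatter), cannot be read.

As far as these compounds go, what remains open is whether the hydroxyl or the second aromatic ring of 2-hydroxynaphthalen-1-yl carries the difference, as naphthalen-1-yl without the hydroxyl would show. From the compounds shown here alone, how a primary amine or a carboxylic acid on the phenyl would compare also stays unknown.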